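A few compounds are considered here, and "the series" means these few. Any claim that something is new, unique, unknown or untested is made for them only; others in the source may bear on it.

Compound 1 `Cn1cccc1-c1cc(-c2cccs2)[nH]c(=O)c1C#N` is tested in a functional assay on DU-145 cells (Homo sapiens) for inhibition, read by sulforhodamine B assay, with a stated time of 48 h; on this read-out higher numbers stand for weaker inhibition of growth and lower numbers for stronger inhibition of growth. There compound 1 reaches only a limit of the assay, > 100000 nM, so its standing rests on the limit of > 100000 nM in this assay, at which 1 of the 2 values shown sits, rather than on a number. Compound 2 `COc1ccc(-c2cc(-c3cccn3C)c(C#N)c(N)n2)cc1OC`, built on another core, gives 91200 nM in this assay. Compound 3 `Cn1cccc1-c1cc(-c2ccccc2)[nH]c(=O)c1C#N` differs from compound 1 by phenyl in place of thiophen-2-yl on an aromatic carbon. Going by the values given here, with no measured step of this kind to lean on, the step of a number no higher from compound 1 to compound 3 (the limit leaves the size open) is expected to stay within the scatter. Compound 3 is therefore estimated at 100000 nM, with a range from 30000 nM to 300000 nM.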

Compound 3, concentration for 50% growth inhibition: > 100000 nM
Compound 3: a limit, no number; the forecaster's own chance of this, stated with the estimate: 70%; the middle value sits exactly at the limit.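

Compound 1 and compound 3 both end at a limit of the assay, not at a number, so the step between them cannot be read: the limit of > 100000 nM in this assay, at which 2 of the 3 values shown sit.
In this assay the compounds shown leave open whether phenyl and thiophen-2-yl differ at all on the shared core.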